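A few compounds are considered here, and "the series" means these few. Any claim that something is new, unique, unknown or untested is made for them only; others in the source may bear on it.

Measured so far:
- compound 1, `O=C(N[C@H]1CCCC[C@@H]1O)c1cn(Cc2ccc(-c3cncnc3)cc2)c2cccnc12`: 104 mL/min/kg
- compound 2, `Cc1cnc2c(C(=O)N[C@H]3CCOC[C@@H]3O)cn(Cc3ccc(-c4ccn(C)n4)cc3)c2c1`: 2.5 mL/min/kg

In an ADME assay on liver for metabolic stability, with Liver microsome (Homo sapiens) as the target, using microsomes (a higher number here means faster removal of the compound, a lower number slower removal), compound 1 gives 104 mL/min/kg, the higher of the two numbers; compound 2 gives 2.5 mL/min/kg, a much lower number that lies beyond the scatter. Compound 3, `N#Cc1ccc(Cn2cc(C(=O)N[C@H]3CCCC[C@@H]3O)c3ncccc32)cc1`, has not been measured. It differs from compound 1 in one place: cyano in place of pyrimidin-5-yl on an aromatic carbon, so cyano in place of pyrimidin-5-yl on an aromatic carbon. For the measured compounds named here, no measured pair shows this change, so the step is expected to be modest, pointing toward slower removal. Compound 3 is thus expected to give 60 mL/min/kg in this assay, between 25 mL/min/kg and 130 mL/min/kg, a step of a 1.7-fold lower number from compound 1 to compound 3 (0.24 log units; within the scatter) from compound 1.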

Compound 3, clearance: 18 mL/min/kg
For compound 3 the middle estimate is 3.3-fold (0.52 log units) above the measured one; measured number below the stated range.
By their numbers in this assay, from the lowest: compound 2; then compound 3; then compound 1.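

In this assay, cyano in place of pyrimidin-5-yl, on an aromatic carbon para to a large group, gives a 5.8-fold lower number from compound 1 to compound 3 (0.76 log units; beyond the scatter). For the compounds shown here, this is the first comparison here that changes one place only, and it shows that the group at this position can by itself shift the number beyond the usual scatter. No measurement here explains the shift. From the compounds shown here alone, it remains open whether an amine, a methoxy group or a carboxylic acid at this place would give a similar number. Whether the step carries over to the core of compound 2 is also unknown.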